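The source may report more compounds than this note shows. Statements on the series, on what has been measured and on what is new or still open speak of the compounds shown alone.

Measured set, values in a functional assay on THP-1 cells (Homo sapiens) for antiproliferative activity, tested at 1 uM; a higher number here means a stronger effect of the compound at the concentration tested, a lower number a weaker effect:
compound 1, `Cc1cc2cc(NS(=O)(=O)Cc3ccc(C(=O)NO)cc3)ccc2n(C)c1=O`: 0%
compound 2, `Cc1cc2ccc(NS(=O)(=O)Cc3ccc(C(=O)NOCc4ccc(O)cc4)cc3)cc2n(C)c1=O`: 0%
compound 3, `COc1ccc(C(=O)NO)cc1CS(=O)(=O)Nc1ccc2c(c1)cc(C)c(=O)n2C`: 0%

Compound 3 stands level with compounds 1 and 2 in this assay at the digits reported. Its nearest neighbour is compound 1 and its furthest is compound 2, and to either the gap is no change at the digits shown, within the scatter. For the measured compounds named here, no step between two measured compounds is singled out, so the series so far is a flat floor with nothing to read off it.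

Compound 4, `Cc1cc2cc(NS(=O)(=O)Cc3cccc(C(=O)NO)c3)ccc2n(C)c1=O`, is not yet measured. Against compound 3 the difference is hydrogen in place of methoxy on an aromatic carbon: methoxy leaves and hydrogen enters, on an aromatic carbon of a six-membered aromatic ring of carbon only, ortho to a large group and para to a hydroxycarbamoyl group. The hydroxycarbamoyl group itself is kept.

Since compound 1 gives 0% and compound 3 gives 0%, the expected step is no change at the digits printed from compound 3 to compound 4 (within the scatter), that is none beyond the scatter in either direction. Compound 4 is therefore expected to give 0% in this assay, with a range from -8% to 10%.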

Compound 4, a percentage reported as inhibition, at one concentration (the size of the read-out at that concentration, not a potency): 0%
Compound 4: the middle estimate sits on the measured number at the digits printed, and the stated range covers the measured number.
By their numbers in this assay, from the lowest: compounds 1, 2, 3 and 4 (each within the scatter of the next).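

Hydrogen in place of methoxy on this aromatic carbon, ortho to a large group and para to a hydroxycarbamoyl group, gives no change at the digits printed from compound 3 to compound 4 (within the scatter) in this assay, the first step in the series read between two compounds that differ in one place. The methoxy group is therefore not what holds the read-out at this level: with hydrogen at the same carbon, compound 4 gives 0% and the read-out stays where it was. A step between two compounds on that floor does not show whether this position matters, and nothing available accounts for the flat read-out.

From the compounds shown here alone, what stays open is whether any group at this aromatic carbon can move the read-out off the floor at the single concentration tested, for instance an amine, a carboxylic acid or a longer alkoxy chain in place of methoxy. Also open, going by these compounds, is whether methoxy and hydrogen would still read alike in a compound of this series that shows a measurable effect in this assay.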